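A few compounds are considered here, and "the series" means these few. Any claim that something is new, unique, unknown or untested is made for them only; others in the source may bear on it.

Three compounds share one core, and differ only in the aromatic ring that hangs from the amidine. Compound 1 `COc1ccc(Cn2nc(-c3ccccc3)c3cc(C(=N)Nc4ccc(N5CCN(C)CC5)cc4)nc(Nc4cc(OC)c(OC)c(OC)c4)c32)cc1` carries a methylpiperazinyl group on that ring, and in a functional assay on HT-1080 cells (Homo sapiens) for cytotoxicity, read by MTT assay, with a stated time of 72 h (on this read-out lower numbers stand for stronger inhibition and higher numbers for weaker inhibition), compound 1 gives 1200 nM. Compound 2 `COc1ccc(Cn2nc(-c3ccccc3)c3cc(C(=N)Nc4cccc(C(F)(F)F)c4)nc(Nc4cc(OC)c(OC)c(OC)c4)c32)cc1` carries a trifluoromethyl group there instead; in this assay compound 2 gives "not determined" (no result reported), no single number, so no comparison between compound 1 and compound 2 can be drawn from these data. Compound 3 `COc1ccc(Cn2nc(-c3ccccc3)c3cc(C(=N)Nc4ccccc4)nc(Nc4cc(OC)c(OC)c(OC)c4)c32)cc1` is the simplest of the three: going from compound 2 to compound 3 the change is hydrogen in place of trifluoromethyl on an aromatic carbon, a hydrogen in place of trifluoromethyl on an aromatic carbon, meta to a large group. Compound 2 has no number, so the size of the step to compound 3 in this assay cannot be computed, and a guess at its direction would rest on nothing measured. For the measured compounds named here, the only anchor is compound 1 at 1200 nM, and on that basis compound 3 is expected to land near 2000 nM, within a range from 500 nM to 8000 nM.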

Compound 3, half-maximal inhibitory concentration: 11100 nM
Beside the measured number, compound 3's estimate is 5.6-fold (0.74 log units) below it; measured number above the stated range.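

In this assay, for the compounds shown here, compound 3 gives the first reading for the amidine's aromatic ring with no added group, so it serves as a baseline for that ring. Going by these compounds alone, putting hydrogen in place of 4-methylpiperazin-1-yl on an aromatic carbon gives a 9.3-fold higher number from compound 1 to compound 3 (0.97 log units; beyond the scatter), so the group on this ring clearly affects the read-out, and of these two compounds the one carrying the 4-methylpiperazin-1-yl group is the more strongly cytotoxic. Within the data shown here, compound 2 has no number, so no step to or from it can be read, and the effect of the trifluoromethyl group remains unknown.

Nothing measured here explains why removing the 4-methylpiperazin-1-yl group changes the number this much.

On these data alone, it remains open whether the whole 4-methylpiperazin-1-yl group is needed, or whether a morpholine ring or a plain dimethylamino group in the same place would give a number close to that of compound 1. As far as these compounds go, it is also open how a carboxylic acid or a longer chain ending in an amine on this ring would compare with the bare ring of compound 3.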